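Replacing 3-fluorophenyl with 4-methoxyphenyl: a flat step expected

A few compounds are considered here, and "the series" means these few. Any claim that something is new, unique, unknown or untested is made for them only; others in the source may bear on it.

- compound 1 `Cc1ccc(NC(=S)N/N=C/c2ccc3ccccc3n2)cc1` gives 85500 nM
- compound 2 `Fc1cccc(NC(=S)N/N=C/c2ccc3ccccc3n2)c1` gives 74700 nM

Within the data shown here, in a functional assay on HT-29 cells (Homo sapiens) for antiproliferative activity, read by sulforhodamine B assay, with a stated time of 72 h (on this read-out lower numbers stand for stronger inhibition and higher numbers for weaker inhibition), compound 2 gives 74700 nM and stands level with compound 1, its only measured neighbour. The next compound, compound 3 `COc1ccc(NC(=S)N/N=C/c2ccc3ccccc3n2)cc1`, keeps the shared core and differs from compound 2 in one place. It has 4-methoxyphenyl in place of 3-fluorophenyl on an amide-type nitrogen.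

Among the measured compounds shown here, only one measured step bears on this change, since it concerns the same place: a 1.1-fold lower number from compound 1 to compound 2 (0.06 log units; within the scatter). That step lies within the scatter, so swapping groups here has so far shown no measurable effect. For the measured compounds named here, this is thin evidence, as no compound with a 4-methoxyphenyl group has been measured yet. The new group could still behave differently, but nothing in the data points in either direction. In this assay no step beyond the scatter is therefore expected. The expected step is a 1.1-fold lower number from compound 2 to compound 3 (0.03 log units; within the scatter), which is an estimate. For compound 3 the estimated value is 70000 nM, with an expected range from 25000 nM to 130000 nM.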

Compound 3, half-maximal inhibitory concentration: 82300 nM
Beside the measured number, compound 3's estimate is 1.2-fold (0.07 log units) below it, and the stated range covers the measured number.
By their numbers in this assay, from the lowest: compounds 2, 3 and 1 (each within the scatter of the next).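

In this assay, the change now reaches a group of a different kind: 4-methoxyphenyl brings an oxygen and a hydrogen-bond acceptor that 3-fluorophenyl lacks, yet the result is a 1.1-fold higher number from compound 2 to compound 3 (0.04 log units; within the scatter). A second comparison isolates a smaller change on the same ring, methoxy in place of methyl on an aromatic carbon, and gives a 1.0-fold lower number from compound 1 to compound 3 (0.02 log units; within the scatter), so all three groups on the amide-type nitrogen now read alike within the scatter, and swapping one aromatic group for another on this nitrogen has yet to produce a measurable change. Nothing measured here explains why these numbers stay so close.

These three compounds cannot show whether any group at this position can shift the number beyond the scatter, since each carries a single substituted phenyl ring. Going by these compounds, a phenyl ring bearing an amine or a carboxylic acid, or a longer alkyl chain in place of the ring on this nitrogen, would test the position more widely, and the effect of changing the shared core remains equally open.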